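Adding a Fluorine to the Fused Ring of Compound 2

The compounds below may be only part of what the source reports. "The series", "measured", "known", "first", "only" and "open" are said of these compounds alone.

Measured so far:
- Compound 1, `CCCS(=O)(=O)N1CC=C(c2ccc3c(c2)CC(C2CCN(Cc4ccccc4)CC2)O3)CC1`: 521 nM
- Compound 2, `CCCc1cnc(N2CCC(C3Cc4cc(C5=CCN(S(=O)(=O)CCC)CC5)ccc4O3)CC2)nc1`: 82 nM

Both compounds were tested in a functional assay on HEK293 cells for agonist activity at Glucose-dependent insulinotropic receptor (Homo sapiens), read by cAMP accumulation, with a stated time of 60 min; a higher number here means that more compound is needed for the effect, a lower number that less compound is needed. Compound 2 gives the lower of the two numbers, with compound 1 the nearest neighbour; the step of a 6.4-fold lower number from compound 1 to compound 2 (0.80 log units; beyond the scatter) comes from exchanging one group on the ring nitrogen.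

Compound 3, `CCCc1cnc(N2CCC(C3Cc4cc(C5=CCN(S(=O)(=O)CCC)CC5)cc(F)c4O3)CC2)nc1`, differs from compound 2 by fluoro in place of hydrogen on an aromatic carbon. For the measured compounds named here, no measured step involves this kind of change: the only step known, from compound 1 to compound 2, alters a different part of the molecule and says nothing about a fluorine on the fused ring. Small single-atom additions to an aromatic ring often leave this type of read-out close to where it started, so the expectation is a step of a 1.2-fold lower number from compound 2 to compound 3 (0.07 log units; within the scatter), which is within the scatter, with no firm direction. Compound 3 is therefore estimated at 70 nM, with a range from 25 nM to 200 nM.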

Compound 3, half-maximal effective concentration: 62 nM
For compound 3 the middle estimate is 1.1-fold (0.05 log units) above the measured one; the measured number falls inside the stated range.
By their numbers in this assay, from the lowest: compounds 3 and 2 (each within the scatter of the next); then compound 1.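

In this assay, fluoro in place of hydrogen on this aromatic carbon gives a 1.3-fold lower number from compound 2 to compound 3 (0.12 log units; within the scatter), so the two numbers cannot be told apart. For the compounds shown here, the earlier compounds said nothing about this part of the molecule: their only step, a 6.4-fold lower number from compound 1 to compound 2 (0.80 log units; beyond the scatter), came from a change on the ring nitrogen and lay beyond the scatter. This carbon, ortho to a fused ring and meta to a large group, can therefore carry one fluorine with no change that this read-out can separate from the ordinary variation between repeated measurements, and no supporting information is available to explain this result.

The compounds shown leave open whether a larger group on the same carbon, such as chlorine, methoxy or a nitrile, would also stay within the scatter or would shift the number clearly in either direction. They also leave open whether fluoro on the other aromatic carbons of the fused system would behave in the same way, since one substitution at one carbon supports no general rule about this ring.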